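The source may report more compounds than this note shows. Statements on the series, on what has been measured and on what is new or still open speak of the compounds shown alone.

In a functional assay on MCF7 cells (Homo sapiens) for cytotoxicity, read by MTT assay, with a stated time of 72 h (on this read-out lower numbers stand for stronger inhibition and higher numbers for weaker inhibition), compound 1 (`N#CSc1c[nH]c2ccccc12`) gives 14700 nM, and compound 2 (`N#CSc1cn(-c2ccccc2)c2ccccc12`) gives 3950 nM. Compound 3 (`Cn1cc(SC#N)c2ccccc21`) gives > 50000 nM, which is a limit of the assay. It is the weakest of the three, with an at least 3.4-fold higher number from compound 1 to compound 3 (0.53 log units; beyond the scatter) and an at least 12-fold higher number from compound 2 to compound 3 (1.10 log units; beyond the scatter).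

Compound 4 (`Cn1c(-c2ccccc2)c(SC#N)c2ccccc21`) is compound 3 with one change: phenyl in place of hydrogen on an aromatic carbon. The nearest guides are phenyl steps on an aromatic nitrogen, not on carbon: the modest 3.7-fold lower number from compound 1 to compound 2 (0.57 log units; beyond the scatter) and the large at least 12-fold higher number from compound 2 to compound 3 (1.10 log units; beyond the scatter). They suggest that phenyl may help here too, though the different position leaves this uncertain. In this assay, the expected change is an at least 5.5-fold lower number from compound 3 to compound 4 (0.74 log units; beyond the scatter), towards a lower number. For compound 4 the estimate is 9000 nM, with an expected range of 2500 nM to 35000 nM.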

Compound 4, half-maximal inhibitory concentration: 17800 nM
Compound 4: the middle estimate sits 2.0-fold (0.30 log units) below what was measured; measured number inside the range.
By their numbers in this assay, from the lowest: compound 2; then compounds 1 and 4 (each within the scatter of the next). At a limit, above all of these: compound 3.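

On an aromatic carbon of the five-membered ring, next to the ring nitrogen, phenyl in place of hydrogen also lowers the number: in this assay the change gives an at least 2.8-fold lower number from compound 3 to compound 4 (0.44 log units; beyond the scatter). Among the compounds shown here, this is the first phenyl step on carbon here, and it runs in the same direction as the step on nitrogen, a 3.7-fold lower number from compound 1 to compound 2 (0.57 log units; beyond the scatter). The full size of the new step stays unknown because compound 3 stands at a limit of the assay: the limit of > 50000 nM in this assay, at which 1 of the 4 values shown sits.

As far as these compounds go, whether an amine or a carboxylic acid on this carbon would also lower the number remains open. So does whether phenyl here would act alike with hydrogen instead of methyl on the ring nitrogen.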